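Changing the aryl group on the urea nitrogen of compound 3

This account rests on a few compounds, and the source may have more. Where it says the series, first, only, none or still open, it means among the compounds named here.

Measured so far in a functional assay on RT-112 cells (Homo sapiens) for antiproliferative activity, read by MTT assay, with a stated time of 72 h; a higher number here means a weaker inhibitor of growth, a lower number a stronger inhibitor of growth:
- compound 1, `COc1cc(Nc2ncnc3c(NC(=O)Nc4ccccc4Cl)cccc23)cc(OC)c1`: 356 nM
- compound 2, `COc1cc(Nc2ncnc3c(NC(=O)Nc4cc(F)cc(F)c4)cccc23)cc(OC)c1`: 2630 nM
- compound 3, `COc1cc(Nc2ncnc3c(NC(=O)Nc4ccc5c(c4)OCCO5)cccc23)cc(OC)c1`: 2750 nM

All three share the same core and differ only in the aryl group carried by the urea nitrogen. Compound 3 gives the highest number of the three, though its value sits within the scatter of compound 2, so the two cannot be ranked. Compound 1 stands apart: the step of a 7.4-fold higher number from compound 1 to compound 2 (0.87 log units; beyond the scatter) and the step of a 7.7-fold higher number from compound 1 to compound 3 (0.89 log units; beyond the scatter) are both beyond the scatter, while a 1.0-fold higher number from compound 2 to compound 3 (0.02 log units; within the scatter) is not.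

Compound 4, `COc1cc(Nc2ncnc3c(NC(=O)Nc4ccc(C(F)(F)F)cc4)cccc23)cc(OC)c1`, is not yet measured. It differs from compound 3 as follows: 4-(trifluoromethyl)phenyl in place of 2,3-dihydro-1,4-benzodioxin-6-yl on an amide-type nitrogen

Going by the values given here, no measured step covers this exact exchange. The two steps that bear on it, from compound 1 to compound 2 and from compound 1 to compound 3, show that leaving the 2-chlorophenyl group cost roughly the same either way, and that the two replacements then sat level with each other. Compound 4 again carries an aryl group other than 2-chlorophenyl, so the expectation is a number close to that of compound 3, with no step beyond the scatter: a 1.4-fold lower number from compound 3 to compound 4 (0.14 log units; within the scatter) is the estimated change. The value expected for compound 4 in this assay is 2000 nM, within a range from 700 nM to 6000 nM.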

Compound 4, concentration for 50% growth inhibition: 3920 nM
Estimate against measurement, compound 4: 2.0-fold (0.29 log units) below, and the stated range covers the measured number.
By their numbers in this assay, from the lowest: compound 1; then compounds 2, 3 and 4 (each within the scatter of the next).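

Compound 4 puts a third replacement for the 2-chlorophenyl group on the urea nitrogen, and in this assay it falls in with the other two (a 1.4-fold higher number from compound 3 to compound 4 (0.15 log units; within the scatter); a 1.5-fold higher number from compound 2 to compound 4 (0.17 log units; within the scatter)), so compounds 2, 3 and 4 cannot be ranked. The exchange from compound 3 removes the non-aromatic ring and its oxygen hydrogen-bond acceptors, yet the step stays within the scatter, so among these compounds neither that ring nor those acceptors separates one from another, while compound 1 remains apart (an 11-fold higher number from compound 1 to compound 4 (1.04 log units; beyond the scatter)). No measurement is available that would explain why 2-chlorophenyl alone stands apart from these three groups.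

The compounds shown leave open whether the chlorine itself matters or its place on the ring, a question that 3-chlorophenyl, 4-chlorophenyl and plain phenyl on the same nitrogen would address. They also leave open whether other groups in the place of the chlorine, such as fluorine, methyl or methoxy in 2-fluorophenyl, 2-methylphenyl or 2-methoxyphenyl, would keep compound 1's number in this assay.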